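The source may report more compounds than this note shows. Statements on the series, on what has been measured and on what is new or still open speak of the compounds shown alone.

Compound 1 `Cc1ccc(CS/C(=C/c2cc(C)ccc2C)C(=O)c2ccc(Cl)cc2)cc1`: 10000 nM
Compound 2 `Cc1ccc(CS/C(=C/c2ccc(C)s2)C(=O)c2ccc(Cl)cc2)cc1`: 50000 nM

Both values come from a functional assay on DU-145 cells (Homo sapiens) for inhibition, read by trypan blue exclusion, with a stated time of 96 h; a lower number here means a stronger inhibitor of growth, a higher number a weaker inhibitor of growth. Compound 2 has the higher number of the two, which makes it the weaker inhibitor of growth, and its gap to compound 1 lies beyond the usual scatter.

Compound 3 `Cc1ccc(CS/C(=C/c2cc([N+](=O)[O-])ccc2F)C(=O)c2ccc(Cl)cc2)cc1` keeps the shared core and changes one group, on a double-bonded chain carbon bound to a double-bonded chain carbon: 2-fluoro-5-nitrophenyl in place of 5-methylthiophen-2-yl on a double-bonded chain carbon bound to a double-bonded chain carbon. Within the data shown here, only one measured step bears on this place, and it is modest: a 5.0-fold higher number from compound 1 to compound 2 (0.70 log units; beyond the scatter). That step brought in 5-methylthiophen-2-yl in place of 2,5-dimethylphenyl, whereas compound 3 removes the same 5-methylthiophen-2-yl and restores a six-membered aromatic ring of carbon only. The direction to expect is therefore towards a lower number in this assay. However, no measured compound carries 2-fluoro-5-nitrophenyl, so the expected step is kept somewhat smaller and stays uncertain. The expected change is a 3.3-fold lower number from compound 2 to compound 3 (0.52 log units; beyond the scatter). Compound 3 is estimated at 15000 nM, with an expected range of 4000 nM to 50000 nM.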

Compound 3, concentration for 50% growth inhibition: 1000 nM
For compound 3 the middle estimate is 15-fold (1.18 log units) above the measured one; measured number below the stated range.
By their numbers in this assay, from the lowest: compound 3; then compound 1; then compound 2.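

In this assay, this place on a double-bonded chain carbon bound to a double-bonded chain carbon proves far more sensitive than the earlier pair suggested: putting 2-fluoro-5-nitrophenyl in place of 5-methylthiophen-2-yl gives a 50-fold lower number from compound 2 to compound 3 (1.70 log units; beyond the scatter), and compound 3 is now the strongest inhibitor of growth among the three. The change from a five-membered to a six-membered ring cannot be the whole story, since 2-fluoro-5-nitrophenyl in place of 2,5-dimethylphenyl, which swaps one six-membered aromatic ring of carbon only for another, still gives a 10-fold lower number from compound 1 to compound 3 (1.00 log units; beyond the scatter), so what the ring carries matters here as well. No measurement is available that explains why the number falls at this place.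

The fluorine and the nitro group enter together in compound 3, so the compounds shown cannot divide the gain between them. Going by these compounds, it also remains open whether a phenyl ring carrying only a nitro group, only a fluorine, or an amine instead of the nitro group would keep a number as low as that of compound 3 in this assay.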